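A few compounds are considered here, and "the series" means these few. Any claim that something is new, unique, unknown or untested is made for them only; others in the source may bear on it.

Compound 1 `COc1cc(NC(=O)NNc2cc(-c3ccccc3)c3cnn(C)c3n2)cc(Cl)n1`: 28700 nM
Compound 2 `COc1ccc(-c2cc(NNC(=O)Nc3cc(Cl)nc(Cl)c3)nc3c2c(C)nn3C)cc1`: 9700 nM
Compound 3 `Cn1ncc2c(-c3ccccc3)cc(NNC(=O)Nc3cc(Cl)nc(Cl)c3)nc21`: 76900 nM
Compound 4 `COc1cc(NC(=O)NNc2cc(-c3ccc(F)cc3)c3cnn(C)c3n2)cc(Cl)n1`: not yet measured

In a functional assay on SW620/5-FU cells (Homo sapiens) for cytotoxicity, read by MTT assay, with a stated time of 48 h, in the presence of a further agent that is not named here (a higher number here means that more compound is needed for the effect, a lower number that less compound is needed), compound 1 holds the second highest of the three numbers. Compound 4 differs from it by fluoro in place of hydrogen on an aromatic carbon, turning phenyl into 4-fluorophenyl: fluoro in place of hydrogen on an aromatic carbon. For the measured compounds named here, the only measured single-place step, a 2.7-fold higher number from compound 1 to compound 3 (0.43 log units; beyond the scatter), is modest and concerns chloro in place of methoxy, not this phenyl, so it shows only the scale of change. Going by the values given here, no measured step covers the new fluoro, and the expected result is a 1.1-fold lower number from compound 1 to compound 4 (0.06 log units; within the scatter), which means no shift beyond the scatter. For compound 4 the estimated value is 25000 nM, with an expected range of 10000 nM to 60000 nM.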

Compound 4, half-maximal effective concentration: 24100 nM
Beside the measured number, compound 4's estimate is 1.0-fold (0.02 log units) above it; measured number inside the range.
By their numbers in this assay, from the lowest: compound 2; then compounds 4 and 1 (each within the scatter of the next); then compound 3.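

In this assay, putting fluoro on the phenyl of the core, para to a large group, gives a 1.2-fold lower number from compound 1 to compound 4 (0.08 log units; within the scatter) and so no shift beyond the scatter. For the compounds shown here, this is the first single-place step at this phenyl, since the earlier one concerned only chloro in place of methoxy. At this place, a single fluoro is accommodated without a readable change in the number.

On these data alone, whether a larger or charged group at the same place, such as an amine or a carboxylic acid, would move the number remains open. No measured evidence bears on this result.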